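Swapping the Side Arm on a Shared Core

The source may hold more compounds than are shown below. What is called first, only, known or untested is meant among the compounds shown, and "the series" means these compounds.

Of the compounds shown here, two with the same core have been measured so far in a functional assay on MGC-803 cells (Homo sapiens) for cytotoxicity, read by MTT assay, with a stated time of 38 h; a lower number here means a stronger inhibitor, a higher number a weaker inhibitor. Compound 1 `COc1cc(OC)c2c(=O)c(OCC(=O)N/N=C/c3sccc3C)c(-c3cc(OC)c(OC)c(OC)c3)oc2c1` gives 7740 nM, while compound 2 `COc1cc(OC)c2c(=O)c(OCC(=O)N/N=C/c3ccccc3F)c(-c3cc(OC)c(OC)c(OC)c3)oc2c1` gives 2780 nM, the lower of the two numbers and so the stronger inhibitor of this pair. The next molecule, compound 3 `COc1cc(OC)c2c(=O)c(OCCCCN3CCCCC3)c(-c3cc(OC)c(OC)c(OC)c3)oc2c1`, keeps the shared core but has a different side arm: a group of 9 heavy atoms (8 carbon, 1 nitrogen; one six-membered non-aromatic ring with 1 hetero atom) in place of a group of 12 heavy atoms (8 carbon, 2 nitrogen, 1 oxygen, 1 fluorine; one six-membered aromatic ring of carbon only), on a saturated chain carbon bound to an oxygen on an aromatic ring. The incoming 3-(piperidin-1-yl)propyl group sits on a saturated chain carbon bound to an oxygen on an aromatic ring.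

Within the data shown here, only one measured step offers any guide: a 2.8-fold lower number from compound 1 to compound 2 (0.44 log units; beyond the scatter), which came from 2-fluorophenyl replacing 3-methylthiophen-2-yl. That step was modest, but it involved a much smaller exchange than this one, and the 2-fluorophenyl group is lost entirely in compound 3. The data therefore show no direction for the new change, so no clear shift in this assay is expected. The estimated change is small: a 1.4-fold higher number from compound 2 to compound 3 (0.16 log units; within the scatter). For compound 3, the expected value is 4000 nM, with an estimated range of 1000 nM to 15000 nM.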

Compound 3, half-maximal inhibitory concentration: 26800 nM
Compound 3: the middle estimate sits 6.7-fold (0.83 log units) below what was measured; measured number outside the range, above it.
By their numbers in this assay, from the lowest: compound 2; then compound 1; then compound 3.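

In this assay, the group on the saturated chain carbon bound to an oxygen on an aromatic ring clearly matters: exchanging the whole side arm for 3-(piperidin-1-yl)propyl gives a 9.6-fold higher number from compound 2 to compound 3 (0.98 log units; beyond the scatter) and likewise a 3.5-fold higher number from compound 1 to compound 3 (0.54 log units; beyond the scatter) in this series. Both steps lie beyond the scatter and point the same way, which makes compound 3 the weakest of the three and shows that this position does not accept every arm equally, at least among these compounds. Nothing in the available data explains why the number rose.

The outgoing arms and the incoming one differ in several ways at once, including the aromatic ring, the hydrogen-bond donor and the piperidine ring, so the compounds shown cannot say which of these differences accounts for the step. A longer or shorter chain ending in the same piperidine ring, or the same chain ending in a morpholine ring or a dimethylamine, would help separate the effect of the chain from that of the amine.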